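Chloro step from compound 2 in the cytotoxicity series

The source may hold more compounds than are shown below. What is called first, only, known or untested is meant among the compounds shown, and "the series" means these compounds.

In an ADME assay on HaCaT cells (Homo sapiens) for cytotoxicity, read by MTT assay, with a stated time of 48 h (on this read-out higher numbers stand for weaker inhibition and lower numbers for stronger inhibition), compound 1 (`Cc1ccc2[nH]c(-c3cn(-c4ccccc4)nc3-c3ccccc3)nc2c1`) gives > 50000 nM as a limit of the assay. Compound 2 (`Cc1cc2nc(-c3cn(-c4ccccc4)nc3-c3ccccc3)[nH]c2cc1C`) gives > 50000 nM as a limit as well. Compound 2 therefore stands without a number, at the limit of > 50000 nM in this assay, at which 2 of the 2 values shown sit, together with compound 1. Among the measured compounds shown here, the only measured step is a step that the two limits leave unreadable from compound 1 to compound 2 and it concerns methyl in place of hydrogen on an aromatic carbon, so it offers no size to carry over. Compound 3 (`Cc1cc2nc(-c3cn(-c4ccccc4)nc3-c3ccc(Cl)cc3)[nH]c2cc1C`) differs from compound 2 by chloro in place of hydrogen on an aromatic carbon in the change from phenyl to 4-chlorophenyl. With no readable step to draw on, no step beyond the usual scatter is expected in either direction, and another limit is quite likely. The expected step is a number no higher from compound 2 to compound 3 (the limit leaves the size open) as estimated here. For compound 3 the estimate is 50000 nM with an expected range of 20000 nM to 100000 nM as a working figure.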

Compound 3, half-maximal inhibitory concentration: > 50000 nM
Compound 3 ended at the assay's limit; the forecaster's own chance of this, stated with the estimate: 70%; the middle value sits exactly at the limit.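

Compound 2 and compound 3 both stand as limits, not numbers, in this assay, so no new step can be read between them: the limit of > 50000 nM in this assay, at which 3 of the 3 values shown sit. The compounds shown leave open how large the methyl and chloro steps are, and whether any of these compounds has a measurable value in this assay.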